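From cyano to a sulfur-bearing group on compound 3

The source may hold more compounds than are shown below. What is called first, only, known or untested is meant among the compounds shown, and "the series" means these compounds.

compound 1 `N#Cc1cn(Cc2ccccc2)c2ncnc(N)c12`: > 100000 nM
compound 2 `Cn1cc(C#N)c2c(N)ncnc21`: > 100000 nM
compound 3 `CCCn1cc(C#N)c2c(N)ncnc21`: > 100000 nM

In a functional assay on KB cells (Homo sapiens) for cytotoxicity (on this read-out lower numbers stand for stronger inhibition and higher numbers for weaker inhibition), compound 3 gives > 100000 nM, which is a limit and not a number. It shares that position with the other two compounds: the limit of > 100000 nM in this assay, at which 3 of the 3 values shown sit.

Compound 4 `CCCn1cc(C(=N)S)c2c(N)ncnc21` keeps the propyl group and alters one place, an aromatic carbon of a five-membered aromatic ring: a group of 3 heavy atoms (1 carbon, 1 nitrogen, 1 sulfur; no ring) in place of a group of 2 heavy atoms (1 carbon, 1 nitrogen; no ring), on an aromatic carbon.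

The measured steps are a step that the two limits leave unreadable from compound 1 to compound 2, a step that the two limits leave unreadable from compound 1 to compound 3 and a step that the two limits leave unreadable from compound 2 to compound 3. All three change the chain on the ring nitrogen and leave the cyano group in place, so they offer no size to carry over to this change.

The expectation therefore rests on one point: with compound 3 reported as the limit > 100000 nM, any readable result can only lie on the side of stronger inhibition. Another limit remains quite possible. The expected step, a modest one towards lower numbers, is an at least 3.3-fold lower number from compound 3 to compound 4 (0.52 log units; beyond the scatter). The estimated value for compound 4 is 30000 nM, with an expected range from 3000 nM to 100000 nM.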

Compound 4, half-maximal inhibitory concentration: 17000 nM
The estimate for compound 4 lay 1.8-fold (0.25 log units) above the measured number; measured number inside the range.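

In this assay the swap of the cyano group for the sulfur-bearing group on this aromatic carbon gives an at least 5.8-fold lower number from compound 3 to compound 4 (0.76 log units; beyond the scatter) with the propyl group unchanged. This is the only change shown that yields a readable step, since the steps among the three cyano compounds, which alter only the chain on the ring nitrogen, cannot be read. So this aromatic carbon is a place where a change of group can move the read-out, and compound 4 alone has a number, while the other compounds stay at a limit: the limit of > 100000 nM in this assay, at which 3 of the 4 values shown sit.

From the compounds shown here alone, whether the sulfur itself matters stays open, and an amide or a carboxylic acid on this aromatic carbon would help to separate its part from that of the rest of the group. Also open, going by these compounds, is how the sulfur-bearing group behaves with a longer chain on the ring nitrogen.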